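The source may report more compounds than this note shows. Statements on the series, on what has been measured and on what is new or still open speak of the compounds shown alone.

Compound 2 `Cc1nn(C(=O)c2cccnc2)c(N)c1-c1ccc(Cl)c(Cl)c1` carries a pyridin-3-yl group on a carbonyl carbon of the shared core. In an assay on Sf9 cells for inhibition of mitogen-activated protein kinase kinase kinase 14 (Homo sapiens), read by ADP-Glo, with a stated time of 60 min (a lower number here means a stronger inhibitor, a higher number a weaker inhibitor), compound 2 gives > 100000 nM, which is a limit of the assay and not a measured number. Its neighbour compound 1 `Cc1nn(C(=O)C2CCC2)c(N)c1-c1ccc(Cl)c(Cl)c1` differs only at that carbonyl carbon, where it bears a cyclobutyl group, and in this assay compound 1 gives 2900 nM. Going by the values given here, the one measured step, an at least 34-fold higher number from compound 1 to compound 2 (1.53 log units; beyond the scatter), is large, and it ends at the limit of > 100000 nM in this assay, at which 1 of the 2 values shown sits, so the full size of the loss stays open. Compound 3 `Cc1nn(C(=O)c2ccncc2)c(N)c1-c1ccc(Cl)c(Cl)c1` brings the next change: pyridin-4-yl in place of pyridin-3-yl on a carbonyl carbon. Among the compounds with values here, no measured step bears directly on this exchange of one pyridyl for another; the only step recorded concerns a different group and is a weak guide here. With compound 2 already at the limit, the expected step of a number no higher from compound 2 to compound 3 (the limit leaves the size open) is none beyond the scatter, with a real chance that compound 3 again returns only a limit. Compound 3 is therefore estimated at 100000 nM, within a range from 20000 nM to 300000 nM.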

Compound 3, half-maximal inhibitory concentration: 58200 nM
Estimate against measurement, compound 3: 1.7-fold (0.24 log units) above; measured number inside the range.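

With pyridin-4-yl on the carbonyl carbon, the cost of giving up the cyclobutyl group now has a measured size in this assay: the change gives a 20-fold higher number from compound 1 to compound 3 (1.30 log units; beyond the scatter), so a large loss is seen with both pyridyl groups shown and not only with the one that ended at a limit. The exchange of one pyridyl group for the other gives an at least 1.7-fold lower number from compound 2 to compound 3 (0.23 log units; that floor lies within the scatter), so this position does not yet show a real difference between the two, although one may exist. The true size of that step stays unknown, as the value of compound 2 is a limit of the assay and not a number: the limit of > 100000 nM in this assay, at which 1 of the 3 values shown sits.

The compounds shown leave open whether the loss follows from the ring nitrogen or from an aromatic ring on the carbonyl carbon as such, a question that a plain phenyl group there would address. They also leave open how pyridin-2-yl would compare, and whether a smaller cyclopropyl or a larger cyclopentyl group would hold or improve on the number given by cyclobutyl.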